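A Chloro Exchanged for Trifluoromethyl in a Small Series

The source may report more compounds than this note shows. Statements on the series, on what has been measured and on what is new or still open speak of the compounds shown alone.

In a functional assay on HepG2 cells (Homo sapiens) for antiproliferative activity, read by MTT assay, with a stated time of 24 h (on this read-out higher numbers stand for weaker inhibition and lower numbers for stronger inhibition), compound 1 `O=S(=O)(c1ccccc1)n1c(-c2cn(-c3ccccc3)nc2-c2ccc(F)cc2)nc2ccccc21` gives 720 nM and compound 2 `COc1ccc(S(=O)(=O)n2c(-c3cn(-c4ccccc4)nc3-c3ccc(F)cc3)nc3ccccc32)cc1`, which carries a methoxy group in place of a hydrogen, gives 470 nM. The measured step between them is a 1.5-fold lower number from compound 1 to compound 2 (0.19 log units; within the scatter). Compound 3 `O=S(=O)(c1ccc(Cl)cc1)n1c(-c2cn(-c3ccccc3)nc2-c2ccc(F)cc2)nc2ccccc21`, the chloro member, gives 4230 nM, the highest number of the three and so the weakest inhibition. It is set apart by a 5.9-fold higher number from compound 1 to compound 3 (0.77 log units; beyond the scatter) and by a 9.0-fold higher number from compound 2 to compound 3 (0.95 log units; beyond the scatter).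

Compound 4 `O=S(=O)(c1ccc(C(F)(F)F)cc1)n1c(-c2cn(-c3ccccc3)nc2-c2ccc(F)cc2)nc2ccccc21` has trifluoromethyl in place of chloro on an aromatic carbon, para to a large group: trifluoromethyl in place of chloro on an aromatic carbon. Within the data shown here, no measured compound carries trifluoromethyl, so the evidence is indirect. Among the measured compounds shown here, the two steps into compound 3 show only that a change at this place can shift the number by a modest amount, and in both of them chloro is the group entering. Leaving chloro could therefore bring the number down, but the data do not show how far with this replacement. The expectation is no step beyond the scatter, with a slight lean towards a lower number. The expected step is a 1.4-fold lower number from compound 3 to compound 4 (0.15 log units; within the scatter). For compound 4 the estimated value in this assay is 3000 nM, with an expected range from 1000 nM to 9000 nM.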

Compound 4, half-maximal inhibitory concentration: 1680 nM
The estimate for compound 4 lay 1.8-fold (0.25 log units) above the measured number; measured number inside the range.
By their numbers in this assay, from the lowest: compounds 2 and 1 (each within the scatter of the next); then compound 4; then compound 3.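

The exchange shows that the high number of compound 3 in this assay does not extend to every group tested at this position: there is a 2.5-fold lower number from compound 3 to compound 4 (0.40 log units; beyond the scatter), a step beyond the scatter, so the two groups can be told apart here. The return is only partial, however, as there is also a 2.3-fold higher number from compound 1 to compound 4 (0.37 log units; beyond the scatter) and a 3.6-fold higher number from compound 2 to compound 4 (0.55 log units; beyond the scatter), both beyond the scatter, which places trifluoromethyl on the side of weaker inhibition relative to both hydrogen and methoxy while still ahead of chloro. Nothing measured here accounts for the gap between chloro and trifluoromethyl at this position.

The compounds shown carry only hydrogen, methoxy, chloro and trifluoromethyl at this position, so it remains open whether an amine, a carboxylic acid or a longer chain such as ethoxy would fall with compound 1 and compound 2 or nearer to compound 3. All four also share the same core, which leaves open whether the exchange of chloro for trifluoromethyl would give a step of similar size with a change made elsewhere on it.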